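The source may hold more compounds than are shown below. What is called first, only, known or untested is meant among the compounds shown, and "the series" means these compounds.

Compound 1 `Nc1ccc(/C=C/C(=O)c2ccc(Cl)cc2)cc1`: 43000 nM
Compound 2 `Nc1ccc(/C=C/C(=O)c2ccc(I)cc2)cc1`: 58000 nM

In a functional assay on HeLa cells (Homo sapiens) for antiproliferative activity, with a stated time of 48 h (on this read-out higher numbers stand for weaker inhibition and lower numbers for stronger inhibition), compound 2 gives 58000 nM, and compound 1 gives 43000 nM; the two stand level within the scatter. Compound 3 `Cc1ccc(C(=O)/C=C/c2ccc(N)cc2)cc1` is still unmeasured. It differs from compound 2 as follows: methyl in place of iodo on an aromatic carbon. For the measured compounds named here, only one measured step bears on this, iodo in place of chloro at that same spot, and it gave a 1.3-fold higher number from compound 1 to compound 2 (0.13 log units; within the scatter). Going by the values given here, no measured compound carries a methyl there, so the evidence is thin. The expected change is small, a 1.2-fold lower number from compound 2 to compound 3 (0.06 log units; within the scatter), with nothing expected beyond the scatter. Compound 3 is estimated at 50000 nM, with an expected range of 22000 nM to 110000 nM.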

Compound 3, half-maximal inhibitory concentration: 40000 nM
The estimate for compound 3 lay 1.3-fold (0.10 log units) above the measured number; measured number inside the range.
By their numbers in this assay, from the lowest: compounds 3, 1 and 2 (each within the scatter of the next).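

In this assay methyl in place of a halogen on this aromatic carbon gives a 1.5-fold lower number from compound 2 to compound 3 (0.16 log units; within the scatter) and also a 1.1-fold lower number from compound 1 to compound 3 (0.03 log units; within the scatter) in the second comparison. The earlier pair compared only two halogens, whereas these steps show that a carbon group also leaves the number level with chloro and iodo here. No measured evidence accounts for this level result. The compounds shown leave open whether an amine, a carboxylic acid or a longer chain on this carbon would move the number beyond the scatter.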